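The source may hold more compounds than are shown below. What is called first, only, known or untested is meant among the compounds shown, and "the series" means these compounds.

Compound 1 `COc1ccnc(-c2cc(Cl)ccc2NS(=O)(=O)c2ccc(C(C)(C)C)cc2)c1` carries a 4-methoxypyridin-2-yl group on the shared core, and in a functional assay on isolated protein for antagonist activity at C-C chemokine receptor type 9 (Homo sapiens), read by calcium flux, with a stated time of 10 min (a higher number here means a weaker inhibitor, a lower number a stronger inhibitor), compound 1 gives 2500 nM, the highest of the two numbers recorded. Among the compounds with values here, its only measured neighbour is compound 2 `CC(C)(C)c1ccc(S(=O)(=O)Nc2ccc(Cl)cc2-c2ncccc2CO)cc1`, which in this assay gives 89 nM; the single step recorded, a 28-fold lower number from compound 1 to compound 2 (1.45 log units; beyond the scatter), replaces the 4-methoxypyridin-2-yl group with 3-(hydroxymethyl)pyridin-2-yl and is large. Compound 3 `CC(C)(C)c1ccc(S(=O)(=O)Nc2ccc(Cl)cc2-c2nccc(C(N)=O)c2O)cc1` is not yet measured. Its difference from compound 1 is a group of 10 heavy atoms (6 carbon, 2 nitrogen, 2 oxygen; one six-membered aromatic ring with 1 hetero atom) in place of a group of 8 heavy atoms (6 carbon, 1 nitrogen, 1 oxygen; one six-membered aromatic ring with 1 hetero atom), on an aromatic carbon: the entering group brings two hydrogen-bond donors and a double bond outside the aromatic ring where the leaving group had none. The step from compound 1 to compound 2 bears on this change, since there too the methoxy-bearing pyridinyl was exchanged for a pyridinyl carrying a hydrogen-bond donor, and it was beyond the scatter. By analogy a lower number is expected for compound 3, though the entering group is not the same, so a smaller step is estimated: a 7.1-fold lower number from compound 1 to compound 3 (0.85 log units; beyond the scatter). Compound 3 is therefore expected to give about 350 nM, within a range from 70 nM to 1800 nM.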

Compound 3, half-maximal inhibitory concentration: 52 nM
Estimate against measurement, compound 3: 6.7-fold (0.83 log units) above; the whole stated range lies above it.
By their numbers in this assay, from the lowest: compounds 3 and 2 (each within the scatter of the next); then compound 1.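

In this assay, the place on an aromatic carbon, ortho to a large group and meta to a chloro group, now shows a second large step away from the 4-methoxypyridin-2-yl group: a 48-fold lower number from compound 1 to compound 3 (1.68 log units; beyond the scatter). The drop seen with compound 2 is therefore not confined to the 3-(hydroxymethyl)pyridin-2-yl group, and the step between the two replacements, a 1.7-fold lower number from compound 2 to compound 3 (0.23 log units; within the scatter), leaves them unseparated in this assay even though the group in compound 3 has more heavy atoms. No measurement is available that would account for the size of either step or for the closeness of compound 2 and compound 3.

On these data alone, the group entering in compound 3 holds a hydroxy group and a primary amide together, so it remains open whether either one alone, on the same pyridinyl ring, would give a number like that of compound 3. As far as these compounds go, it is also open whether the methoxy group of compound 1 or its ring position matters more, and how a carboxylic acid or an amine would behave in this place.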